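Iodo in place of isopropyl: compound 3 to compound 4

The source may report more compounds than this note shows. Statements on the series, on what has been measured and on what is new or still open speak of the compounds shown alone.

Compound 3 `CCCC(=O)Nc1ccc(S(=O)(=O)Oc2ccccc2C(C)C)cc1` has the lowest of the three measured numbers. In a functional assay on M21 cells (Homo sapiens) for antiproliferative activity, read by sulforhodamine B assay, with a stated time of 48 h (on this read-out higher numbers stand for weaker inhibition and lower numbers for stronger inhibition), compound 3 gives 6100 nM. Compound 2 `CCC(=O)Nc1ccc(S(=O)(=O)Oc2ccccc2I)cc1` gives 11000 nM, which lies within the scatter of compound 3, while compound 1 `CC(=O)Nc1ccc(S(=O)(=O)Oc2ccccc2I)cc1` gives 27000 nM, beyond the scatter. Compound 4 `CCCC(=O)Nc1ccc(S(=O)(=O)Oc2ccccc2I)cc1` differs from compound 3 by iodo in place of isopropyl on an aromatic carbon. For the measured compounds named here, the only measured single-place step, a 2.5-fold lower number from compound 1 to compound 2 (0.39 log units; beyond the scatter), concerns the amide chain, so no measured step bears on the aryl change. Compounds 2 and 3 carry iodo and isopropyl but also differ in the chain; their values lie within the scatter of each other. No step beyond the scatter is therefore expected in this assay. Compound 4 is estimated at 7000 nM, range 3000 nM to 18000 nM. The expected step is a 1.1-fold higher number from compound 3 to compound 4 (0.06 log units; within the scatter).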

Compound 4, half-maximal inhibitory concentration: 9000 nM
Compound 4: middle estimate off by 1.3-fold (0.11 log units), on the low side; the range from low to high includes it.
By their numbers in this assay, from the lowest: compounds 3, 4 and 2 (each within the scatter of the next); then compound 1.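

In this assay, iodo in place of isopropyl on this aromatic carbon, with the amide chain held fixed, does not separate the two groups (a 1.5-fold higher number from compound 3 to compound 4 (0.17 log units; within the scatter)). On the chain, methyl in place of hydrogen two bonds along from the carbonyl carbon stays within the scatter (a 1.2-fold lower number from compound 2 to compound 4 (0.09 log units; within the scatter)), whereas ethyl in place of hydrogen on the carbon bound to the carbonyl carbon goes beyond it (a 3.0-fold lower number from compound 1 to compound 4 (0.48 log units; beyond the scatter)). No evidence is available on what lies behind these steps.

Still open, as far as these compounds go, is whether a longer chain, or an amine or carboxylic acid at its end, moves the values beyond the scatter. Also open, from the compounds shown here alone, is how a methoxy group or fluoro on this aromatic carbon compares with iodo.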